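The source may hold more compounds than are shown below. What is called first, only, known or untested is meant among the compounds shown, and "the series" means these compounds.

Compound 1 `O=C(Nc1cccc(-n2cc(-c3ccncc3)c(-c3cc(O)cc(Cl)c3)n2)c1)Nc1ccc(Cl)c(C(F)(F)F)c1` gave 35.3%. Compound 2 `COc1cc(Cl)cc(-c2nn(-c3cccc(NC(=O)Nc4cc(C(F)(F)F)cc(C(F)(F)F)c4)c3)cc2-c2ccncc2)c1` gave 3.93%. Compound 3 `COc1cc(Cl)cc(-c2nn(-c3cccc(NC(=O)Nc4ccc(Cl)c(Cl)c4)c3)cc2-c2ccncc2)c1` gave 7.39%.

All three were tested in a functional assay on HT-29 cells (Homo sapiens) for inhibition, read by sulforhodamine B assay, with a stated time of 48 h, tested at 10 uM; on this read-out lower numbers stand for a stronger effect and higher numbers for a weaker effect at the one concentration tested. Compound 3 stands second highest of the three numbers; its value and that of compound 2 lie within the scatter of each other, while compound 1 sits well above both, beyond the scatter. Compound 4 `COc1cc(Cl)cc(-c2nn(-c3cccc(NC(=O)c4cccc(C(F)(F)F)c4)c3)cc2-c2ccncc2)c1` differs from compound 3 in one place: 3-(trifluoromethyl)phenyl in place of (3,4-dichlorophenyl)amino on a carbonyl carbon. No measured pair shows a change of this kind, so the direction of the step rests on no precedent among these compounds. The expected step, a number 12.6 percentage points higher from compound 3 to compound 4 (beyond the scatter), is a moderate rise, meaning a somewhat weaker effect, though it may also stay within the scatter. Compound 4 is therefore estimated at 20%, with a range from 5% to 50%.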

Compound 4, a percentage reported as activity, at one concentration (the size of the read-out at that concentration, not a potency): 42.5%
Compound 4: middle estimate off by 22.5 percentage points, on the low side; measured number inside the range.
By their numbers in this assay, from the lowest: compounds 2 and 3 (each within the scatter of the next); then compounds 1 and 4 (each within the scatter of the next).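

On this assay the group on this carbonyl carbon matters: 3-(trifluoromethyl)phenyl in place of (3,4-dichlorophenyl)amino gives a number 35.1 percentage points higher from compound 3 to compound 4 (beyond the scatter) and so a much weaker effect. The change removes the amino nitrogen, with its hydrogen-bond donor, and also replaces the two chlorines with trifluoromethyl, so this single step cannot show which part accounts for the loss. Nothing measured here explains the weaker effect.

Which part of the change carries the loss remains open. So does the effect of a smaller group on this carbonyl carbon, such as a methylamino group or a morpholine ring.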